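Methyl on the carboxy-bearing ring carbon: solubility notes

The source may hold more compounds than are shown below. What is called first, only, known or untested is meant among the compounds shown, and "the series" means these compounds.

In a physicochemical assay for solubility, read by turbidimetry, in phosphate buffer, with a stated time of 24 h, at pH 7.4 (on this read-out higher numbers stand for higher solubility and lower numbers for lower solubility), compound 1 `CCNC(=O)Nc1nc2cc(-c3cccnc3)cc(-c3ccccn3)c2s1` gives 6.25 ug/mL. Compound 2 `CCNC(=O)Nc1nc2cc(-c3cnc(N4CCC(C(=O)O)CC4)nc3)cc(-c3ccccn3)c2s1` is reported in this assay only as a limit, > 800 ug/mL, so its position is not a number. Compound 2 thus stands at the limit of > 800 ug/mL in this assay, at which 1 of the 2 values shown sits. The remaining member, compound 3 `CCNC(=O)Nc1nc2cc(-c3cnc(N4CCC(C)(C(=O)O)CC4)nc3)cc(-c3ccccn3)c2s1`, has not yet been measured in this assay. Against compound 2 the change is methyl in place of hydrogen on a saturated ring carbon. Going by the values given here, no measured step of this kind is available, so the expectation rests on compound 2 alone: a small shift is anticipated, of a size that is expected to stay within the usual scatter, an at least 1.1-fold lower number from compound 2 to compound 3 (0.05 log units; that floor lies within the scatter). Compound 3 is therefore expected to give about 700 ug/mL in this assay, with a likely range from 300 ug/mL to 900 ug/mL, and a fair chance that only a limit is again reported.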

Compound 3, solubility: > 800 ug/mL
Compound 3: only a limit was reported; the forecaster's own chance of this, stated with the estimate: 55%; at least 1.1-fold (0.05 log units) between middle value and limit.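

Going by these compounds alone, compound 2 and compound 3 are both reported only as limits in this assay, and no step between them can be read. The compounds shown leave open whether methyl in place of hydrogen on a saturated ring carbon shifts this read-out at all.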